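From an Ethoxy to a Benzylsulfanyl Group on the Core

The compounds below may be only part of what the source reports. "The series", "measured", "known", "first", "only" and "open" are said of these compounds alone.

Of the compounds shown here, three sharing one core have been measured in an ADME assay on BCBL1 cells (Homo sapiens) for cytotoxicity, with a stated time of 7 days; a higher number here means that more compound is tolerated, a lower number that less compound is tolerated. Compound 1 `Nc1nc(NC2CC2)c2ncn(/C=C3/CC3(CO)CO)c2n1` carries a cyclopropylamino group, and in this assay compound 1 gives 71500 nM. Compound 2 `CCCSc1nc(N)nc2c1ncn2/C=C1/CC1(CO)CO` carries a propylsulfanyl group in its place. For compound 2 this assay returns only > 20000 nM, which is a limit of the assay and not a number. Compound 3 `CCOc1nc(N)nc2c1ncn2/C=C1/CC1(CO)CO` carries an ethoxy group at the same position. For compound 3 the assay likewise returns only > 20000 nM, again a limit rather than a number. Because of the limit of > 20000 nM in this assay, at which 2 of the 3 values shown sit, the step from compound 1 to compound 2 a step that the limit leaves unreadable from compound 1 to compound 2, the step from compound 1 to compound 3 a step that the limit leaves unreadable from compound 1 to compound 3 and the step from compound 2 to compound 3 a step that the two limits leave unreadable from compound 2 to compound 3 all stay unreadable, so compound 3 can be placed only as lying at that limit, alongside compound 2.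

Compound 4 `Nc1nc(SCc2ccccc2)c2ncn(/C=C3/CC3(CO)CO)c2n1` is not yet measured. Within the data shown here, it differs from compound 3 in one place: benzylsulfanyl in place of ethoxy on an aromatic carbon No measured step involves a benzylsulfanyl group, so none bears directly on this change, and the limits hide the size of the steps that do exist. The direction of the step from compound 3 to compound 4 is therefore taken as uncertain, and it is estimated as a number no higher from compound 3 to compound 4 (the limit leaves the size open) in this assay. Compound 4 is expected to give about 20000 nM in this assay, within a range from 6000 nM to 70000 nM.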

Compound 4, half-maximal cytotoxic concentration: > 20000 nM
Compound 4: a limit, no number (the forecaster's own chance of this, stated with the estimate: 40%); the middle value sits exactly at the limit.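

In this assay compound 4 gives > 20000 nM, which is a limit of the assay and not a number. No step linking compound 4 to compound 1, compound 2 or compound 3 can be read, because of this: the limit of > 20000 nM in this assay, at which 3 of the 4 values shown sit.

The compounds shown leave open how far the benzylsulfanyl, propylsulfanyl, ethoxy and cyclopropylamino groups differ in how much compound is tolerated.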